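The source may hold more compounds than are shown below. What is called first, only, known or untested is meant among the compounds shown, and "the series" means these compounds.

Measured so far:
compound 1, `CN(C)CCNc1ccnc2cc(OCc3ccc(F)cc3)ccc12`: 780 nM
compound 2, `CC(C)COc1ccc2c(Cl)ccnc2c1`: 2100 nM

Both numbers come from a functional assay on NCI-H1650 cells (Homo sapiens) for cytotoxicity, read by MTT assay, with a stated time of 48 h; a higher number here means a weaker inhibitor, a lower number a stronger inhibitor. Compound 1 gives the lower of the two; compound 2 sits clearly higher, and that gap is beyond the usual scatter. Compounds 1 and 2 differ in more than one place, so no single step can be read between them, and only their two values are known.

Compound 3, `C=CCOc1ccc2c(NCCN(C)C)ccnc2c1`, has not yet been tested in this assay. It differs from compound 1 in one place: vinyl in place of 4-fluorophenyl on a saturated chain carbon bound to an oxygen on an aromatic ring. Put another way, a 4-fluorobenzyl group on the aryl oxygen becomes an allyl group. Among the measured compounds shown here, no measured pair shows what this kind of change does here, so the expectation rests on compound 1 alone. A modest weakening is expected, amounting to an estimated step of a 1.9-fold higher number from compound 1 to compound 3 (0.28 log units; within the scatter). Compound 3 is therefore expected to give about 1500 nM, with a likely range from 600 nM to 4000 nM.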

Compound 3, half-maximal inhibitory concentration: 930 nM
The estimate for compound 3 lay 1.6-fold (0.21 log units) above the measured number; the measured number falls inside the stated range.
By their numbers in this assay, from the lowest: compounds 1 and 3 (each within the scatter of the next); then compound 2.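

In this assay, cutting the 4-fluorobenzyl group on the aryl oxygen down to an allyl group gives a 1.2-fold higher number from compound 1 to compound 3 (0.08 log units; within the scatter) and so leaves the two compounds indistinguishable. Among the compounds shown here, this is the first single-place change that can be read at this position, and it shows that the six-membered aromatic ring and its fluorine can leave, with vinyl taking their place, without a change beyond the scatter. No supporting measurement is available to explain why the two compounds match.

Still open, on these data alone, is whether a saturated propyl group, a longer chain, or a chain ending in an amine or a carboxylic acid would also keep the number in this range. For the compounds shown here, with only one step at this position, it is also unknown whether changes elsewhere on the shared core would be tolerated in the same way.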